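This account rests on a few compounds, and the source may have more. Where it says the series, first, only, none or still open, it means among the compounds named here.

Compound 1, `Cc1ccccc1C(=O)OC(CCN(C)C)c1ccc(Cl)cc1`, gives 126% in an assay on NIH3T3 cells with Urotensin-2 receptor (Homo sapiens) as the target; on this read-out lower numbers stand for smaller maximal responses and higher numbers for larger maximal responses.
Compound 2, `CN(C)CCC(NC(=O)c1ccccc1)c1ccc(Cl)cc1`, gives 158% in this assay.

Of these two measured compounds, compound 1 stands lowest in this assay; the nearest value, that of compound 2, lies higher by an amount beyond the usual scatter. The unmeasured compound 3, `Cc1ccccc1NC(=O)OC(CCN(C)C)c1ccc(Cl)cc1`, differs from compound 1 in one place: (2-methylphenyl)amino in place of 2-methylphenyl on a carbonyl carbon. Compound 2 also carries a nitrogen-hydrogen donor and reaches the larger response, so a modest rise is expected; the step of a number 14 percentage points higher from compound 1 to compound 3 (beyond the scatter) is estimated to lie near the edge of the scatter. Compound 3 is therefore expected to give about 140%, with a likely range from 110% to 175%.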

Compound 3, largest response reached (reported as efficacy), in percent of the reference or control that the assay uses: 176%
Compound 3: the middle estimate sits 36 percentage points below what was measured, outside the stated range (above it).
By their numbers in this assay, from the lowest: compound 1; then compound 2; then compound 3.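

Putting (2-methylphenyl)amino in place of 2-methylphenyl on a carbonyl carbon gives a number 50 percentage points higher from compound 1 to compound 3 (beyond the scatter) in this assay. This position is therefore sensitive: a single change here, which brings in a hydrogen-bond donor, shifts the maximal response by a large step. No available evidence explains the rise. From the compounds shown here alone, it remains open whether the hydrogen on the new nitrogen matters, which a methylated nitrogen in the same place could test. Going by these compounds, it also remains open whether a chlorine in place of the methyl on the ring would keep the response.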